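A few compounds are considered here, and "the series" means these few. Any claim that something is new, unique, unknown or untested is made for them only; others in the source may bear on it.

Working notes on a short polyamine series. Compound 1 `CCCNCCCNCCCNCCC` is a straight chain with secondary amines; compound 2 `CCCNCCCNCCCCN` is obtained from it by aminomethyl in place of propylamino on a saturated chain carbon, three bonds along the chain from an amine nitrogen. Compound 3 `CCCNCCCCNCCCCN` is a related chain, and the difference between the core of compound 3 and that of compound 1 is not broken down here. Compound 4 `NCCCCCNCCCCN` has not yet been measured.

In a functional assay on L1210 cells (Mus musculus) for inhibition, with a stated time of 48 h (on this read-out lower numbers stand for stronger inhibition and higher numbers for weaker inhibition), compound 1 gives only a limit, > 100000 nM. In the same read-out compound 2 also gives only a limit, > 100000 nM. For the measured compounds named here, compound 3 is the only member with a number in this assay, namely 100000 nM. The step that the two limits leave unreadable from compound 1 to compound 2 cannot be read because of the limit of > 100000 nM in this assay, at which 2 of the 3 values shown sit.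

The change from compound 3 to compound 4 is aminomethyl in place of propylamino on a saturated chain carbon, four bonds along the chain from an amine nitrogen. It is the same kind of change as that from compound 1 to compound 2, but not the same: the place is four bonds along the chain from an amine nitrogen rather than three. The measured pair gives no size for this change. Compound 3 itself gives 100000 nM, and the expectation for compound 4 is that it stays near that value. Compound 4 is expected to give about 150000 nM in this assay, with a range of 50000 nM to 500000 nM. The step of a 1.5-fold higher number from compound 3 to compound 4 (0.18 log units; within the scatter) is accordingly expected to be within scatter.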

Compound 4, half-maximal inhibitory concentration: > 100000 nM
Compound 4: a limit, no number; the forecaster's own chance of this, stated with the estimate: 55%; the middle value lies beyond the limit too.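

In this assay, for the compounds shown here, putting aminomethyl in place of propylamino on the core of compound 3 gives a number no lower from compound 3 to compound 4 (the limit leaves the size open) and so shows only that the number does not fall on this core. Compound 4 gives > 100000 nM as a limit of the assay and not a number. The steps that involve two limits cannot be read, so the same kind of change at three bonds along the chain from an amine nitrogen gives no size to compare, and carrying the change from one core to another stays unresolved because the values pile up at one limit: the limit of > 100000 nM in this assay, at which 3 of the 4 values shown sit.

The compounds shown leave open whether any change on these chains gives a number clearly lower than that of compound 3, which gives 100000 nM as the only number in the series. A butylamino group or a carboxylic acid in place of aminomethyl on the same chain carbon, or a longer chain on the core of compound 3, could be read against that number in this assay only if the value came out as a number and not as a limit.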